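A few compounds are considered here, and "the series" means these few. Any claim that something is new, unique, unknown or untested is made for them only; others in the source may bear on it.

Working notes on the series. Compound 1 `O=C(/C=C/c1cccc(/C=C/C(=O)c2ccccc2)c1)NO` gives 3210 nM in a functional assay on K562 cells (Homo sapiens) for antiproliferative activity, read by MTT assay, with a stated time of 72 h; a lower number here means a stronger inhibitor, a higher number a weaker inhibitor. Compound 3 `O=C(/C=C/c1cccc(/C=C/C(=O)c2ccccc2)n1)NO` gives 510 nM in this assay; the difference between the cores of compound 1 and compound 3 is not broken down here. Compound 2 `CN1CCN(c2cccc(C(=O)/C=C/c3cccc(/C=C/C(=O)NO)n3)c2)CC1` gives 110 nM in this assay, the change from compound 3 being (4-methylpiperazin-1-yl in place of hydrogen on an aromatic carbon), with a step of a 4.6-fold lower number from compound 3 to compound 2 (0.67 log units; beyond the scatter). Compound 4 `CN1CCN(c2ccccc2C(=O)/C=C/c2cccc(/C=C/C(=O)NO)c2)CC1` is not yet measured in this assay; it differs from compound 1 by 4-methylpiperazin-1-yl in place of hydrogen on an aromatic carbon. This is the same kind of change as that from compound 3 to compound 2, not the same one: in compound 2 the group sits meta to a large group, in compound 4 ortho to a large group. The step from compound 1 to compound 4 in this assay is expected to be a 2.9-fold lower number from compound 1 to compound 4 (0.47 log units; beyond the scatter). This expectation rests on a 4.6-fold lower number from compound 3 to compound 2 (0.67 log units; beyond the scatter); the place around the group and the core are not the same, so a somewhat smaller step is taken. Compound 4 is estimated at about 1100 nM, between 400 nM and 3500 nM.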

Compound 4, half-maximal inhibitory concentration: 1290 nM
Estimate against measurement, compound 4: 1.2-fold (0.07 log units) below; measured number inside the range.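

In this assay, 4-methylpiperazin-1-yl in place of hydrogen on an aromatic carbon gives a 2.5-fold lower number from compound 1 to compound 4 (0.40 log units; beyond the scatter), so the number also falls on this second core. The two steps with this change cannot be told apart: the same change on two cores in this assay, a 4.6-fold lower number (0.67 log units; beyond the scatter) from compound 3 to compound 2 and a 2.5-fold lower number (0.40 log units; beyond the scatter) from compound 1 to compound 4, 1.9-fold (0.27 log units) apart, within the scatter of two such steps. This shows agreement in direction and no measurable difference in size across one pair of cores, but it is no general rule for the series, and core and place change together, with the group ortho to a large group in compound 4 but not in compound 2.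

As far as these compounds go, whether a morpholine ring or a dimethylamino group would give a similar step remains open. Also open, from the compounds shown here alone, is how the step depends on place on a single core.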